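Para-fluoro on the benzylidene ring: cytotoxicity outlook

The source may hold more compounds than are shown below. What is called first, only, known or untested is meant among the compounds shown, and "the series" means these compounds.

Compound 1, `O=C(CN1C(=O)S/C(=C\c2ccccc2)C1=O)NOCc1ccccc1`, in an ADME assay on RAW264.7 cells (Mus musculus) for cytotoxicity, read by neutral red uptake, with a stated time of 24 h (a lower number here means that less compound is tolerated, a higher number that more compound is tolerated), gives > 128000 nM, a limit of the assay.
Compound 2, `C=CCONC(=O)CN1C(=O)S/C(=C\c2ccccc2)C1=O`, in this assay gives > 128000 nM, again a limit.
Compound 3, `C=CCONC(=O)C(C)N1C(=O)S/C(=C\c2ccccc2)C1=O`, in this assay gives > 128000 nM, also a limit.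

Compound 2 therefore stands at the assay limit, as do its two neighbours; (the limit of > 128000 nM in this assay, at which 3 of the 3 values shown sit). The step that the two limits leave unreadable from compound 1 to compound 2 and the step that the two limits leave unreadable from compound 2 to compound 3 are both unreadable for that reason. Compound 4, `C=CCONC(=O)CN1C(=O)S/C(=C\c2ccc(F)cc2)C1=O`, differs from compound 2 by fluoro in place of hydrogen on an aromatic carbon. Among the measured compounds shown here, no measured step can size this change, so the expectation rests on compound 2 sitting at the limit > 128000 nM. The step that the limit leaves unreadable from compound 2 to compound 4 is expected to stay within the scatter, and compound 4 is estimated at 200000 nM, between 128000 nM and 400000 nM.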

Compound 4, half-maximal cytotoxic concentration: > 128000 nM
Compound 4: no number, only a limit (the forecaster's own chance of this, stated with the estimate: 90%); the middle value does not contradict the limit.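

Compound 2 and compound 4 both sit at the assay limit, so no size can be read for the change from phenyl to 4-fluorophenyl: the limit of > 128000 nM in this assay, at which 4 of the 4 values shown sit.
In this assay the compounds shown leave open the concentration at which any of them becomes toxic to the cells.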